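The source may hold more compounds than are shown below. What is called first, only, known or untested is meant among the compounds shown, and "the series" means these compounds.

Compound 1 `CCCCn1nc(-c2cccnc2)c2ccccc2c1=O`: 91%
Compound 2 `O=c1c2ccccc2c(-c2cccnc2)nn1Cc1ccccc1`: 97%

In an assay on isolated protein (Oryctolagus cuniculus) with Thromboxane-A synthase (Homo sapiens) as the target, tested at 1 uM (on this read-out higher numbers stand for more inhibition at the one concentration tested (going by the name of the read-out) and lower numbers for less inhibition), compound 2 gives 97%, which places it at the top of the two numbers. Among the measured compounds shown here, the only other number belongs to compound 1, and the step of a number 6 percentage points higher from compound 1 to compound 2 (within the scatter) lies within the scatter, so the two compounds cannot be told apart on this read-out. Compound 3 `O=c1c2ccccc2c(-c2cccnc2)nn1Cc1cccc(Cl)c1` is the next compound, differing from compound 2 by chloro in place of hydrogen on an aromatic carbon, a single chlorine added to the ring that hangs off the saturated chain carbon. For the measured compounds named here, the one measured step, a swap of a propyl chain for a phenyl ring, touches the same part of the molecule but is a different kind of change, so it bears on this step only loosely; it was itself within the scatter. With nothing pointing to a change beyond the scatter, and compound 2 already near the upper end of the percentage scale, compound 3 is expected to stay close, with a step of a number 3 percentage points lower from compound 2 to compound 3 (within the scatter). The estimate for compound 3 is 94%, within 82% to 99%.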

Compound 3, a percentage reported as inhibition, at one concentration (the size of the read-out at that concentration, not a potency): 95%
Compound 3: the middle estimate sits 1 percentage points below what was measured; the range from low to high includes it.
By their numbers in this assay, from the lowest: compounds 1, 3 and 2 (each within the scatter of the next).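

In this assay, adding a chlorine to the ring of the benzyl group, which turns benzyl into 3-chlorobenzyl, gives a step that stays within the scatter (a number 2 percentage points lower from compound 2 to compound 3 (within the scatter)), so on this read-out this ring carbon takes the new atom with no change that can be detected. Set against the propyl end of compound 1, the 3-chlorophenyl end also gives a step within the scatter (a number 4 percentage points higher from compound 1 to compound 3 (within the scatter)), so three different ends on the saturated chain carbon now give numbers that cannot be told apart, where the earlier compounds offered only two. Nothing measured here offers an explanation for this closeness.

Going by these compounds, all three compounds sit near the top of the percentage scale at the single concentration tested, so it remains open whether they would differ in potency if tested across a range of concentrations. On these data alone, it also remains open whether a more different group on the same ring carbon, such as a carboxylic acid or an amine in place of the chloro, would move the number beyond the scatter.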